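A few compounds are considered here, and "the series" means these few. Any claim that something is new, unique, unknown or untested is made for them only; others in the source may bear on it.

Measured so far:
- Compound 1 `NC1=NC2(CCSCC2)N(OCCCOc2cccc(Cl)c2)C(N)=N1`: no result in an assay on isolated protein for inhibition of Dihydrofolate reductase (Homo sapiens), read by spectrophotometry, using NADPH, with stated times of 5 s and 6 min; a lower number here means a stronger inhibitor, a higher number a weaker inhibitor ("not determined" (no result reported))
- Compound 2 `NC1=NC2(CCSCC2)N(OCCCOc2cccc(Cl)c2Cl)C(N)=N1`: no result in this assay ("not determined" (no result reported))
- Compound 3 `NC1=NC2(CCOCC2)N(OCCCOc2ccc(Cl)cc2)C(N)=N1`: 33.6 nM in this assay

Compound 2 stands without a number: this assay gave no result for it, and compound 1, which shares its core, is in the same position. Within the data shown here, the only measured value in the set belongs to compound 3, which in this assay gives 33.6 nM.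

The step of interest leads from compound 2 to compound 4 `NC1=NC2(CCSCC2)N(OCCCOc2ccc(Cl)cc2)C(N)=N1`. The change is 4-chlorophenyl in place of 2,3-dichlorophenyl on an oxygen on a saturated carbon. Among the measured compounds shown here, because no two measured compounds differ in one place, no step has been measured, and the size of the step in this assay cannot be read from the data. There is no figure for compound 2 to serve as a starting point, so no direction can be claimed for the step from compound 2 to compound 4 beyond the scatter of the method.

What remains is the value of compound 3, which carries the same 4-chlorophenyl as compound 4 and differs from it only in the core. On that basis compound 4 is expected to give about 30 nM in this assay, with a likely range from 10 nM to 100 nM.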

Compound 4, half-maximal inhibitory concentration: 18.3 nM
For compound 4 the middle estimate is 1.6-fold (0.21 log units) above the measured one, within the range that was stated.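

In this assay compound 4 gives 18.3 nM but compound 2 has no single number to set against it, so no step can be read between them. The compounds shown leave open how 4-chlorophenyl in place of 2,3-dichlorophenyl changes inhibition on the shared core. Nothing shown here offers an explanation for the value of compound 4.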